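An Ester Tail in Place of a Hydroxyalkyl Chain

A few compounds are considered here, and "the series" means these few. Any claim that something is new, unique, unknown or untested is made for them only; others in the source may bear on it.

Compound 1 `CCCCS(=O)(=O)Nc1cc(-c2ccc3c(c2)N(Cc2ccncc2)C(=O)CO3)cnc1OC` and compound 2 `COc1ncc(-c2ccc3c(c2)N=C(N2CCN(CCCO)CC2)CO3)cc1NS(=O)(=O)c1ccc(F)cc1F` have been tested in a functional assay on HCT-116 cells (Homo sapiens) for antiproliferative activity, read by sulforhodamine B assay, with a stated time of 72 h; on this read-out higher numbers stand for weaker inhibition and lower numbers for stronger inhibition. Compound 1 gives 41400 nM. Compound 2 gives 3260 nM, the lowest of the two numbers and well apart from compound 1, beyond the scatter. Compound 3 `CCOC(=O)CN1CCN(C2=Nc3cc(-c4cnc(OC)c(NS(=O)(=O)c5ccc(F)cc5F)c4)ccc3OC2)CC1` has not yet been measured in this assay. It differs from compound 2 by ethoxycarbonyl in place of 2-hydroxyethyl on a saturated chain carbon bound to an amine nitrogen in a ring. For the measured compounds named here, no measured pair shows this change, so its effect is unknown. The expected step is a 1.2-fold higher number from compound 2 to compound 3 (0.09 log units; within the scatter), a shift within the scatter. In this assay compound 3 is estimated at 4000 nM, with a range from 1500 nM to 12000 nM.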

Compound 3, half-maximal inhibitory concentration: 14500 nM
Compound 3: middle estimate off by 3.6-fold (0.56 log units), on the low side; measured number outside the range, above it.
By their numbers in this assay, from the lowest: compound 2; then compound 3; then compound 1.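

In this assay, ethoxycarbonyl in place of 2-hydroxyethyl on a saturated chain carbon bound to an amine nitrogen in a ring gives a 4.4-fold higher number from compound 2 to compound 3 (0.65 log units; beyond the scatter) and so shows that this position responds to the change, with compound 2 the better of the pair. The change swaps a hydrogen-bond donor for none and adds heavy atoms, but the pair cannot separate these differences. Nothing available accounts for the step. On these data alone, whether a carboxylic acid, an amide or a longer hydroxyalkyl chain at this place would match compound 2 remains open.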